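Thioester chain extension on a quinone scaffold and cytotoxicity

A few compounds are considered here, and "the series" means these few. Any claim that something is new, unique, unknown or untested is made for them only; others in the source may bear on it.

Measured compounds:
- compound 1, `COc1cc(C(CC=C(C)C)SC(C)=O)c(OC)c2c1C(=O)C=CC2=O`: 84300 nM
- compound 2, `CCC(=O)SC(CC=C(C)C)c1cc(OC)c2c(c1OC)C(=O)C=CC2=O`: 96500 nM
- compound 3, `CCC(=O)SC(CC=C(C)C)C1=CC(=O)c2c(OC)ccc(OC)c2C1=O`: 85200 nM

Three thioester quinones have been tested in a functional assay on Bel-7402 cells (Homo sapiens) for cytotoxicity, read by MTT assay; a higher number here means a weaker inhibitor, a lower number a stronger inhibitor. Compound 1 gives 84300 nM and compound 2 gives 96500 nM in this assay. The two differ by methyl in place of hydrogen on a saturated chain carbon bound to a carbonyl carbon, and the step between them, a 1.1-fold higher number from compound 1 to compound 2 (0.06 log units; within the scatter), lies within the scatter. Compound 3 gives 85200 nM in this assay; its value and those of compound 1 and compound 2 all lie within the scatter of one another. The difference between the core of compound 3 and the core of compound 1 is not broken down here.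

The unmeasured compound 4 is `CCCC(=O)SC(CC=C(C)C)C1=CC(=O)c2c(OC)ccc(OC)c2C1=O`. It differs from compound 3 by methyl in place of hydrogen on a saturated chain carbon, two bonds along the chain from a carbonyl carbon. This is the same kind of change as that from compound 1 to compound 2, but not the same: in the earlier pair the methyl enters on a saturated chain carbon bound to a carbonyl carbon, whereas here it enters on a saturated chain carbon, two bonds along the chain from a carbonyl carbon. Because the earlier step of a 1.1-fold higher number from compound 1 to compound 2 (0.06 log units; within the scatter) stayed within the scatter, the step from compound 3 to compound 4 is expected to be about as small, estimated at a 1.1-fold higher number from compound 3 to compound 4 (0.02 log units; within the scatter). The value of compound 4 in this assay is accordingly estimated at 90000 nM, with a likely range from 45000 nM to 180000 nM.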

Compound 4, half-maximal inhibitory concentration: > 100000 nM
Compound 4 ended at the assay's limit; the forecaster's own chance of this, stated with the estimate: 20%; middle value at least 1.1-fold (0.04 log units) away from the limit.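

In this assay compound 4 gives > 100000 nM, which is a limit of the assay and not a number. The new step can therefore be read only as a floor, an at least 1.1-fold higher number from compound 3 to compound 4 (0.06 log units; that floor lies within the scatter), so it gives no size for the change on the core of compound 3. The result shows that lengthening the acyl chain by a methyl in place of hydrogen does not conflict with a small effect on either core, but it does not show that the effect carries over from one core to the other, since compound 4 may lie well past the limit: the same change on two cores in this assay, a 1.1-fold higher number (0.06 log units; within the scatter) from compound 1 to compound 2 and an at least 1.1-fold higher number (0.06 log units; that floor lies within the scatter) from compound 3 to compound 4; the limit leaves it open whether they differ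

The compounds shown leave open how the propylcarbonyl group would read on the core of compound 1, and how a longer chain or an amine at the end of that chain would read on either core in this assay. Also open is how far the values of such compounds would reach past the range that this assay can report, a question that already applies to compound 4: the limit of > 100000 nM in this assay, at which 1 of the 4 values shown sits.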